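Methoxy position swap on the aryl imine of compound 3

A few compounds are considered here, and "the series" means these few. Any claim that something is new, unique, unknown or untested is made for them only; others in the source may bear on it.

Measured so far in a functional assay on P388 cells (Mus musculus) for cytotoxicity, read by MTT assay, with a stated time of 72 h; a higher number here means a weaker inhibitor, a lower number a stronger inhibitor:
compound 1 `Cc1c(/N=C/c2cccc(O)c2)c(=O)n(-c2ccccc2)n1C` gives 437000000 nM
compound 2 `Cc1c(/N=C/c2ccccc2Cl)c(=O)n(-c2ccccc2)n1C` gives 324000000 nM
compound 3 `COc1cccc(/C=N/c2c(C)n(C)n(-c3ccccc3)c2=O)c1` gives 105000000 nM

Compound 3 holds the lowest number of the three in this assay. One step is a 3.1-fold lower number from compound 2 to compound 3 (0.49 log units; beyond the scatter), and the other is a 4.2-fold lower number from compound 1 to compound 3 (0.62 log units; beyond the scatter); both steps lie beyond the scatter, so compound 3 counts as the strongest of the three. The remaining step, a 1.3-fold lower number from compound 1 to compound 2 (0.13 log units; within the scatter), is within the scatter.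

Compound 4 `COc1ccccc1/C=N/c1c(C)n(C)n(-c2ccccc2)c1=O` is the next member. The change from compound 3 is 2-methoxyphenyl in place of 3-methoxyphenyl on a carbon with a double bond to nitrogen. Within the data shown here, no measured step moves a group around the aryl ring of the imine with the rest held fixed. The nearest comparisons are the exchanges of whole aryl groups: the step of a 3.1-fold lower number from compound 2 to compound 3 (0.49 log units; beyond the scatter) and the step of a 1.3-fold lower number from compound 1 to compound 2 (0.13 log units; within the scatter), which together show that swapping one aryl pattern for another in this assay has so far moved the number by a modest amount at most. A positional swap of the same methoxy group is therefore expected to give a step in this assay of about a 1.5-fold higher number from compound 3 to compound 4 (0.18 log units; within the scatter), most likely within the scatter, with a lean toward a higher number since compound 3 already holds the lowest value.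

Compound 4 is estimated at 160000000 nM in this assay, with a range from 60000000 nM to 420000000 nM.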

Compound 4, half-maximal inhibitory concentration: 229000000 nM
Beside the measured number, compound 4's estimate is 1.4-fold (0.16 log units) below it, and the stated range covers the measured number.
By their numbers in this assay, from the lowest: compound 3; then compounds 4, 2 and 1 (each within the scatter of the next).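

In this assay, moving the methoxy group with the atoms unchanged gives a 2.2-fold higher number from compound 3 to compound 4 (0.34 log units; beyond the scatter) and so, beyond the scatter, 2-methoxyphenyl and 3-methoxyphenyl are not interchangeable on the carbon with a double bond to nitrogen. Compound 4 does not separate from the other two analogues, with a 1.4-fold lower number from compound 2 to compound 4 (0.15 log units; within the scatter) and a 1.9-fold lower number from compound 1 to compound 4 (0.28 log units; within the scatter) both reading as within the scatter, which leaves compound 3 as the strongest of the four. No measured data in hand account for this difference between the two methoxy placements.

Open, going by these compounds, is whether the hydroxy and chloro groups respond to relocation on the aryl ring as methoxy does. Also open, on these data alone, is how an amine, a carboxylic acid or a longer ether chain such as ethoxy would read in place of methoxy.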